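Solubility of a Furan-Amine Series: Moving to Naphthyl

A few compounds are considered here, and "the series" means these few. Any claim that something is new, unique, unknown or untested is made for them only; others in the source may bear on it.

Measured compounds:
compound 1 `Fc1ccc(Oc2ccc3c(NCCCNCc4ccco4)ccnc3c2)cc1` — 14500 nM
compound 2 `CC(C)(C)c1ccc(-c2ccc3c(NCCCNCc4ccco4)ccnc3c2)cc1` — 32000 nM

Two compounds share the furanylmethylamine-propyl-amino core and differ only at one aromatic carbon. In a physicochemical assay for solubility, with a stated time of 18 h, at pH 7.4 (on this read-out lower numbers stand for lower solubility and higher numbers for higher solubility), compound 1 gives 14500 nM, and compound 2 gives 32000 nM. Going by the values given here, the single measured step is a 2.2-fold higher number from compound 1 to compound 2 (0.34 log units; beyond the scatter). Compound 2 therefore stands highest of the two numbers in this assay, its nearest neighbour being compound 1.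

Compound 3 `c1coc(CNCCCNc2ccnc3cc(-c4cccc5ccccc45)ccc23)c1` has not yet been measured. Its difference from compound 2 is naphthalen-1-yl in place of 4-(tert-butyl)phenyl on an aromatic carbon: the group that leaves and the group that enters have the same count of heavy atoms, all carbon, with no hydrogen-bond donors or acceptors on either side; the entering group carries two six-membered aromatic rings of carbon only, the leaving group one.

Among the compounds with values here, only one measured step exists, and it concerns an exchange of 4-fluorophenoxy for 4-(tert-butyl)phenyl, not the present exchange, so it bears on the new step only loosely; it was modest in size. Within the data shown here, with no closer precedent, the expected step is a 1.5-fold lower number from compound 2 to compound 3 (0.16 log units; within the scatter), meaning no change beyond the scatter is anticipated in this assay. Compound 3 is thus estimated at 22000 nM, within a range from 8000 nM to 60000 nM.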

Compound 3, solubility: 32000 nM
For compound 3 the middle estimate is 1.5-fold (0.16 log units) below the measured one, within the range that was stated.
By their numbers in this assay, from the lowest: compound 1; then compounds 2 and 3 (each within the scatter of the next).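

In this assay, placing naphthalen-1-yl in place of 4-(tert-butyl)phenyl on this aromatic carbon gives no change at the digits printed from compound 2 to compound 3 (within the scatter), so a second six-membered aromatic ring of carbon only, at the same count of heavy atoms, does not separate the two compounds on this read-out. The gap to 4-fluorophenoxy now appears with a second group, as naphthalen-1-yl in place of 4-fluorophenoxy gives a 2.2-fold higher number from compound 1 to compound 3 (0.34 log units; beyond the scatter), matching in size the step already seen with 4-(tert-butyl)phenyl; the two groups with a ring of carbon only and no ether oxygen thus stand together, with compound 1 apart from them, although three compounds are too few to make this a general rule. Nothing in hand accounts for either step.

On these data alone, it remains open whether the other naphthyl attachment, naphthalen-2-yl, would match naphthalen-1-yl at this carbon, and whether the same holds with a simple phenyl group carrying no tert-butyl. A group of a different kind here, such as morpholine or a carboxylic acid, is also untested among the compounds shown, so how far the number can move at this position is unknown.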